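Pyrazolyl exchange on compound 1: working notes

The source may hold more compounds than are shown below. What is called first, only, known or untested is meant among the compounds shown, and "the series" means these compounds.

Values so far in an ADME assay on BaF3 cells (Mus musculus) for inhibition, read by CellTiter-Glo, with a stated time of 72 h; on this read-out lower numbers stand for stronger inhibition of growth and higher numbers for weaker inhibition of growth
- compound 1 `Cc1cc(Nc2ncc3c(n2)N(C)C(=O)N(c2cc(NC(=O)c4ccc(CN5CCC(N(C)C)C5)c(C(F)(F)F)c4)ccc2C)C3)n(C)n1` gives 509 nM
- compound 2 `Cc1ccc(Nc2ncc3c(n2)N(C)C(=O)N(c2cc(NC(=O)c4ccc(-n5cccc5)c(C(F)(F)F)c4)ccc2C)C3)cn1` gives 317 nM

Compound 1 lies within the scatter of compound 2, so the two cannot be ranked on these numbers. Compound 3 `Cc1ccc(NC(=O)c2ccc(CN3CCC(N(C)C)C3)c(C(F)(F)F)c2)cc1N1Cc2cnc(Nc3cnn(C)c3)nc2N(C)C1=O` is not yet measured and differs from compound 1 by a single exchange 1-methyl-1H-pyrazol-4-yl in place of 1,3-dimethyl-1H-pyrazol-5-yl on a nitrogen on an aromatic ring on a nitrogen on an aromatic ring. Among the compounds with values here, no measured pair tests this exchange, so the expectation is loose. A moderate move to a lower number is expected, and the estimated 3.0-fold lower number from compound 1 to compound 3 (0.48 log units; beyond the scatter) gives its size in this assay with wide uncertainty. Compound 3 is estimated at 170 nM (range 40 nM to 650 nM)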

Compound 3, concentration for 50% growth inhibition: 414 nM
For compound 3 the middle estimate is 2.4-fold (0.39 log units) below the measured one; measured number inside the range.
By their numbers in this assay, from the lowest: compounds 2, 3 and 1 (each within the scatter of the next).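

In this assay, within the data shown here, the exchange to 1-methyl-1H-pyrazol-4-yl on a nitrogen on an aromatic ring gives a 1.2-fold lower number from compound 1 to compound 3 (0.09 log units; within the scatter) and provides the first single-place reading at this position. On this one step, the two pyrazolyl groups cannot be told apart, and the additional methyl of the leaving group shows no effect beyond the scatter. Nothing available accounts for this result. Going by these compounds, whether a phenyl carrying a morpholine or an unsubstituted 1H-pyrazol-4-yl at this nitrogen would move the number beyond the scatter stays open. Compound 2 differs from compound 1 in more than one place, so it cannot settle this.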